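A sulfur swap at the limit of the assay

This account rests on a few compounds, and the source may have more. Where it says the series, first, only, none or still open, it means among the compounds named here.

In an ADME assay on cells (Fibroblast, Gallus gallus) for cytotoxicity, read by CCK-8 assay, with a stated time of 48 h (a lower number here means that less compound is tolerated, a higher number that more compound is tolerated), compound 1 (`CCc1ccc(CN[C@H]2CC(C(=O)O)=C[C@@H](OC(CC)CC)[C@@H]2NC(C)=O)cc1`) gives > 200000 nM, which is a limit and not a number. Compound 2 (`CCC(CC)O[C@@H]1C=C(C(=O)O)C[C@H](NCc2cccc(OC)c2)[C@H]1NC(C)=O`) gives > 200000 nM, again a limit. Compound 3 (`CCC(CC)Oc1cccc(CN[C@H]2CC(C(=O)O)=C[C@@H](OC(CC)CC)[C@@H]2NC(C)=O)c1`) gives > 200000 nM, also a limit. Compound 3 therefore stands with the others, at the limit of > 200000 nM in this assay, at which 3 of the 3 values shown sit.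

Compound 4 (`CCC(CC)O[C@@H]1C=C(C(=O)O)C[C@H](NCc2cccc(SC(C)CC)c2)[C@H]1NC(C)=O`) carries (sec-butyl)sulfanyl in place of (pentan-3-yl)oxy on an aromatic carbon, meta to a large group: (sec-butyl)sulfanyl in place of (pentan-3-yl)oxy on an aromatic carbon.

Two measured changes bear on this one. Replacing 4-ethylphenyl with 3-methoxyphenyl is a step that the two limits leave unreadable from compound 1 to compound 2, and placing pentan-3-yl instead of methyl on the oxygen is a step that the two limits leave unreadable from compound 2 to compound 3. Within the data shown here, neither has a size that can be carried over, and no measured compound here contains sulfur. The expected result in this assay is therefore no clear shift in either direction, with the estimated step being a step that the limit leaves unreadable from compound 3 to compound 4. The most likely report is another limit. If a number is obtained, the estimate for compound 4 is 250000 nM, within an expected range of 80000 nM to 600000 nM.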

Compound 4, half-maximal cytotoxic concentration: > 200000 nM
Compound 4: no number, only a limit; the forecaster's own chance of this, stated with the estimate: 85%; the middle value is on the limit's open side.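

In this assay compound 4 gives > 200000 nM, again a limit and not a number. No step from compound 2 or compound 3 to compound 4 can be read, because all the values are limits: the limit of > 200000 nM in this assay, at which 4 of the 4 values shown sit.

The compounds shown leave open at what concentration any of them harms the cells, and whether (sec-butyl)sulfanyl in place of (pentan-3-yl)oxy changes that concentration.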